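The compounds below may be only part of what the source reports. "The series", "measured", "known", "first", "only" and "open" are said of these compounds alone.

Measured so far in a functional assay on PC-3 cells (Homo sapiens) for cytotoxicity, read by MTT assay, with a stated time of 72 h; a lower number here means a stronger inhibitor, a higher number a weaker inhibitor:
Compound 1 `Cc1cc(=O)n(-c2cccc(F)c2)nc1C(=O)Nc1ccc(Oc2ncnc3[nH]ccc23)cc1` gives 14600 nM.
Compound 2 `Cc1ccc(-n2nc(C(=O)Nc3ccc(Oc4ncnc5[nH]ccc45)cc3)c(C)cc2=O)cc1` gives 9610 nM.
Compound 3 `Cc1cc(=O)n(-c2cccc(F)c2)nc1C(=O)Nc1ccc(Oc2ncnc3c2ccn3C)c(F)c1` gives 8990 nM.

Compounds 1 and 2 differ in a single place: 4-methylphenyl in place of 3-fluorophenyl on an aromatic nitrogen. That change made a step of a 1.5-fold lower number from compound 1 to compound 2 (0.18 log units; within the scatter) in this assay. Compound 4 `Cc1ccc(-n2nc(C(=O)Nc3ccc(Oc4ncnc5c4ccn5C)c(F)c3)c(C)cc2=O)cc1` has not been measured yet; it differs from compound 3 by 4-methylphenyl in place of 3-fluorophenyl on an aromatic nitrogen, the same change at the same place. The difference between the core of compound 3 and the core of compound 1 is not broken down here. Because the earlier step of a 1.5-fold lower number from compound 1 to compound 2 (0.18 log units; within the scatter) was small, the same change is expected to make a similarly small step this time. Compound 4 is therefore expected to show a step of a 1.4-fold lower number from compound 3 to compound 4 (0.14 log units; within the scatter) in this assay, close to the earlier one. The estimate for compound 4 in this assay is 6500 nM, expected to fall between 3000 nM and 14000 nM.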

Compound 4, half-maximal inhibitory concentration: 50500 nM
The estimate for compound 4 lay 7.8-fold (0.89 log units) below the measured number; measured number outside the range, above it.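

In this assay, putting 4-methylphenyl in place of 3-fluorophenyl on the aromatic nitrogen gave a 5.6-fold higher number from compound 3 to compound 4 (0.75 log units; beyond the scatter), so the change did not carry over from one core to the other with the same size or direction: the same change on two cores in this assay, a 1.5-fold lower number (0.18 log units; within the scatter) from compound 1 to compound 2 and a 5.6-fold higher number (0.75 log units; beyond the scatter) from compound 3 to compound 4, 8.5-fold (0.93 log units) apart, beyond the scatter of two such steps

For these two pairs, then, the result of this swap depends on the core that carries it, and a step seen on one core is a poor guide to the step on the other. It does not show which difference between the core of compound 1 and the core of compound 3 is responsible, and two pairs set no rule for the whole series.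

The compounds shown leave open how a plain phenyl or a 4-methoxyphenyl on that nitrogen would behave on each core. Singling out the responsible core difference would take compounds that carry only one of those differences.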